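A few compounds are considered here, and "the series" means these few. Any claim that something is new, unique, unknown or untested is made for them only; others in the source may bear on it.

Compound 1 `COc1ccc(-c2nnc(SCC(=O)Nc3ccc(C(C)=O)cc3)n2-c2ccccc2)cc1` gives 63% in a functional assay on the whole organism (strain albino) for inhibition, with Rattus norvegicus as the target, read by paw edema, with stated times of 30 min and 4 h, at a dose of 0.28 mmol/kg by the oral route; a higher number here means more inhibition at the dose given (going by the name of the read-out), a lower number less inhibition. Compound 2 `COc1cc(-c2nnc(SCC(=O)Nc3ccc(C(C)=O)cc3)n2-c2ccccc2)cc(OC)c1OC` gives 68% in this assay. Compound 3 `CCn1c(SCC(=O)Nc2ccc(C(C)=O)cc2)nnc1-c1ccccc1` gives 69% in this assay.

Compound 3 stands highest of the three numbers, yet its gaps to compound 2 and to compound 1 both lie within the scatter, so no order among them can be claimed. Compound 4 `CC(=O)c1ccc(NC(=O)CSc2nnc(-c3ccccc3)n2-c2ccccc2)cc1` differs from compound 3 by phenyl in place of ethyl on an aromatic nitrogen. Among the measured compounds shown here, the only measured step, a number 5 percentage points higher from compound 1 to compound 2 (within the scatter), concerns the aromatic carbon and was within the scatter, so it bears on the nitrogen change at most indirectly; compounds 1 and 2, which carry phenyl on that nitrogen, sit within the scatter of compound 3. The expected step is therefore a number 4 percentage points lower from compound 3 to compound 4 (within the scatter), none beyond the scatter. Compound 4 is estimated at 65%, within 52% to 77%.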

Compound 4, a percentage reported as inhibition, in the whole organism at one dose (the size of the read-out at that dose, not a potency): 67%
Beside the measured number, compound 4's estimate is 2 percentage points below it; the measured number falls inside the stated range.
By their numbers in this assay, from the lowest: compounds 1, 4, 2 and 3 (each within the scatter of the next).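

In this assay, the aromatic nitrogen accepts phenyl as well as ethyl: the step is a number 2 percentage points lower from compound 3 to compound 4 (within the scatter). On the aromatic carbon, the plain phenyl group does not separate from either methoxylated ring, with a number 1 percentage points lower from compound 2 to compound 4 (within the scatter) and a number 4 percentage points higher from compound 1 to compound 4 (within the scatter). Nothing measured here offers an explanation for these results. Going by these compounds, it remains open whether an amine or a carboxylic acid on that nitrogen, or a chain longer than ethyl, would move the inhibition beyond the scatter.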